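The compounds below may be only part of what the source reports. "The series", "measured", "known", "first", "only" and "open" are said of these compounds alone.

Measured so far in an ADME assay on HepG2 cells (Homo sapiens) for cytotoxicity, read by MTT assay, with a stated time of 72 h; on this read-out lower numbers stand for higher toxicity in this test and higher numbers for lower toxicity in this test:
- compound 1 `Cc1ccc(-c2cc3nc(N)[nH]c(=O)c3s2)cc1`: "nd(insoluble)" (no result reported)
- compound 2 `CCCCNc1nc2cc(-c3ccc(C)cc3)sc2c(=O)[nH]1`: 6000 nM
- compound 3 `CCC(CC)Nc1nc2cc(-c3ccc(C)cc3)sc2c(=O)[nH]1`: 101000 nM

Compound 2 stands lowest of the two numbers obtained in this assay; its nearest neighbour is compound 3, separated from it by a 17-fold higher number from compound 2 to compound 3 (1.23 log units; beyond the scatter). Compound 1 returned no number at all.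

Compound 4 `Cc1ccc(-c2cc3nc(NC(C)c4ccccc4)[nH]c(=O)c3s2)cc1` differs from compound 2 as follows: 1-phenylethyl in place of butyl on a nitrogen on an aromatic ring. Within the data shown here, the only measured step that bears on this is the one from compound 2 to compound 3, which is also an exchange of the butyl on that nitrogen for another group, and it was large: a 17-fold higher number from compound 2 to compound 3 (1.23 log units; beyond the scatter). A step in the same direction, towards a higher number in this assay, is therefore expected for compound 4, although with a single comparison to go on its size is uncertain, and compound 1 is a reminder that this assay may give no result for a member of this series.

Compound 4 is expected to give about 30000 nM in this assay, within a range of 6000 nM to 150000 nM. This estimate corresponds to an expected 5.0-fold higher number from compound 2 to compound 4 (0.70 log units; beyond the scatter).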

Compound 4, half-maximal cytotoxic concentration: 9200 nM
Compound 4: the middle estimate sits 3.3-fold (0.51 log units) above what was measured; the measured number falls inside the stated range.
By their numbers in this assay, from the lowest: compounds 2 and 4 (each within the scatter of the next); then compound 3.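

In this assay, 1-phenylethyl in place of butyl on the nitrogen gives a 1.5-fold higher number from compound 2 to compound 4 (0.19 log units; within the scatter) and so brings in a six-membered aromatic ring of carbon only with no step beyond the scatter. Against pentan-3-yl, the same group gives an 11-fold lower number from compound 3 to compound 4 (1.04 log units; beyond the scatter); the high number of compound 3 therefore does not extend to every replacement of butyl at this position and, among the compounds shown, belongs to pentan-3-yl alone. Nothing available gives a reason for the gap between pentan-3-yl and 1-phenylethyl.

Open, from the compounds shown here alone, is whether cyclohexyl, a longer chain or a chain ending in an amine or a carboxylic acid on this nitrogen would group with compound 3 or with compounds 2 and 4. Also open, going by these compounds, is whether the 4-methylphenyl group shared by these compounds has any bearing on the gap.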